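Fluoro in place of hydrogen on the benzoyl ring, two cores

This account rests on a few compounds, and the source may have more. Where it says the series, first, only, none or still open, it means among the compounds named here.

Compound 1 `O=C(CSc1nc(Cc2c(Cl)cccc2Cl)cc(=O)[nH]1)c1ccccc1` and compound 2 `O=C(CSc1nc(Cc2c(Cl)cccc2Cl)cc(=O)[nH]1)c1ccc(F)cc1` share one core; compound 3 `CCc1c(Cc2c(F)cccc2Cl)nc(SCC(=O)c2ccccc2)[nH]c1=O` and compound 4 `CCc1c(Cc2c(F)cccc2Cl)nc(SCC(=O)c2ccc(F)cc2)[nH]c1=O` share another, and the difference between the two cores is not broken down here. In an ADME assay on MT4 cells (Homo sapiens) for cytotoxicity, read by MTT assay (a higher number here means that more compound is tolerated, a lower number that less compound is tolerated), compound 1 gives > 12000 nM, which is a limit of the assay and not a number. In this assay compound 2 gives > 59000 nM, again a limit. In this assay compound 3 gives > 12000 nM, also a limit. Compound 2 differs from compound 1 by fluoro in place of hydrogen on an aromatic carbon, and the step that the two limits leave unreadable from compound 1 to compound 2 cannot be sized because the limit of > 12000 nM in this assay, at which 2 of the 3 values shown sit, and the limit of > 59000 nM in this assay, at which 1 of the 3 values shown sits, are both limits. Compound 4 differs from compound 3 by fluoro in place of hydrogen on an aromatic carbon; the place reads the same word for word, so this is the same change. All that the first pair shows is that both of its members sit at a limit. For compound 4 the step that the limit leaves unreadable from compound 3 to compound 4 is expected. This rests on compound 3 sitting at > 12000 nM and on the first pair staying at limits. Compound 4 is estimated at 30000 nM, within 12000 nM to 100000 nM.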

Compound 4, half-maximal cytotoxic concentration: > 57000 nM
Compound 4: only a limit was reported; the forecaster's own chance of this, stated with the estimate: 80%; middle value at least 1.9-fold (0.27 log units) from the limit.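

In this assay compound 3 gives > 12000 nM, a limit of the assay and not a number. In this assay compound 4 gives > 57000 nM, again a limit. No step can be read from compound 3 to compound 4. The compounds shown leave open how large the phenyl to 4-fluorophenyl change is in either core, or whether it shifts the tolerated concentration at all.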